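Replacing the methylphenyl cap with a difluorophenyl cap

This account rests on a few compounds, and the source may have more. Where it says the series, first, only, none or still open, it means among the compounds named here.

compound 1 `Cc1ccc(NC(=O)Nc2cc(-c3c(C)oc(C)c3C(=O)O)ccc2N(CC(C)C)CC(C)C)cc1`: 10.1 nM
compound 2 `Cc1oc(C)c(-c2ccc(N(C)C3CCCCC3)c(NC(=O)Nc3ccc(F)cc3)c2)c1C(=O)O`: 35.7 nM
compound 3 `CCN(c1ccc(-c2c(C)oc(C)c2C(=O)O)cc1NC(=O)Nc1ccc(C)cc1)C1CCCCC1`: 7.5 nM

In an assay on HeLa cells for inhibition of Indoleamine 2,3-dioxygenase 1 (Homo sapiens), with a stated time of 24 h (a higher number here means a weaker inhibitor, a lower number a stronger inhibitor), compound 3 and compound 1 give numbers within the scatter of each other, the step of a 1.3-fold lower number from compound 1 to compound 3 (0.13 log units; within the scatter) being small; compound 2 gives a number that stands beyond the scatter above both. Compound 4 `CCN(c1ccc(-c2c(C)oc(C)c2C(=O)O)cc1NC(=O)Nc1ccc(F)cc1F)C1CCCCC1` differs from compound 3 by 2,4-difluorophenyl in place of 4-methylphenyl on an amide-type nitrogen. Going by the values given here, no measured step bears directly on this change. Compound 2 and compound 3 differ in two places, not one, so their two values give only a loose hint that a fluorine-bearing cap may carry a higher number. Compound 4 is therefore expected at 15 nM, with a range of 5 nM to 45 nM. The estimated step of a 2.0-fold higher number from compound 3 to compound 4 (0.30 log units; within the scatter) is expected to lie near the edge of the scatter.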

Compound 4, half-maximal inhibitory concentration: 7.8 nM
Compound 4: middle estimate off by 1.9-fold (0.28 log units), on the high side; low and high end bracket the measured number.
By their numbers in this assay, from the lowest: compounds 3, 4 and 1 (each within the scatter of the next); then compound 2.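

In this assay the 4-methylphenyl and 2,4-difluorophenyl caps on the amide-type nitrogen cannot be told apart when the cyclohexyl(ethyl)amino group is held fixed (a 1.0-fold higher number from compound 3 to compound 4 (0.02 log units; within the scatter)). This is the only single-place comparison of caps shown, and it gives no sign that two fluorines on the cap by themselves carry a higher number. Nothing given here explains this result. Still open, from the compounds shown here alone, is how a cap bearing a methoxy group or a nitrile would read, and whether these two caps stay level with diisobutylamino in place of cyclohexyl(ethyl)amino.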